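Swapping the amide substituent at the cytotoxicity ceiling

The source may report more compounds than this note shows. Statements on the series, on what has been measured and on what is new or still open speak of the compounds shown alone.

Measured so far in an ADME assay on BHK-21 cells (Mesocricetus auratus) for cytotoxicity, with a stated time of 3 days; on this read-out higher numbers stand for lower toxicity in this test and lower numbers for higher toxicity in this test:
- compound 2, `O=C(CCSc1nnc(-c2ccncc2)s1)Nc1ccc(Cl)cc1Cl`, gives > 50000 nM, a limit of the test.
- compound 3, `CC(CSc1nnc(-c2ccncc2)s1)C(=O)Nc1ccc(Cl)cc1Cl`, gives > 50000 nM, likewise a limit.
- compound 1, `CC(Sc1nnc(-c2ccncc2)s1)C(=O)NCc1ccc(Cl)cc1`, has "not determined" (no result reported).

Compound 2 therefore sits at the limit of > 50000 nM in this assay, at which 2 of the 3 values shown sit, so its true reading is not a number but a ceiling. Among the compounds with values here, the one measured step that touches its chemistry, a step that the two limits leave unreadable from compound 2 to compound 3, cannot be sized, since both ends are limits. The unmeasured compound 4, `O=C(CCSc1nnc(-c2ccncc2)s1)NCc1ccccc1`, differs from compound 2 by benzyl in place of 2,4-dichlorophenyl on an amide-type nitrogen. Within the data shown here, no measured pair reports a readable step for this kind of exchange on the amide nitrogen, so there is no basis to expect a shift in this assay in either direction beyond the scatter. Compound 4 is accordingly expected to return another limit, with an estimate of 60000 nM between 25000 nM and 200000 nM. The estimated step from compound 2 to compound 4, a step that the limit leaves unreadable from compound 2 to compound 4, is expected to be essentially none.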

Compound 4, half-maximal cytotoxic concentration: 18700 nM
Beside the measured number, compound 4's estimate is 3.2-fold (0.51 log units) above it, outside the stated range (below it).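

In this assay, within the data shown here, benzyl in place of 2,4-dichlorophenyl on the amide-type nitrogen brings an at least 2.6-fold lower number from compound 2 to compound 4 (0.42 log units; beyond the scatter) and so gives the first readable change in this set. Compound 4 thus moves off the ceiling to a true number, showing that this position can shift the read-out toward higher toxicity in this test, whereas the methyl step on the chain cannot be read, both its ends being limits. The size of the new step remains a minimum, because the reading for compound 2 is a limit: the limit of > 50000 nM in this assay, at which 2 of the 4 values shown sit.

The compounds shown do not separate the loss of the two chlorines from the change from a ring directly on the nitrogen to benzyl; both happen in one step. A plain phenyl or a 2,4-dichlorobenzyl on that nitrogen would pull these two changes apart.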